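The source may hold more compounds than are shown below. What is called first, only, known or untested is meant among the compounds shown, and "the series" means these compounds.

Measured in a functional assay on MDA-MB-231 cells (Homo sapiens) for inhibition, read by CCK-8 assay, with a stated time of 48 h; on this read-out higher numbers stand for weaker inhibition of growth and lower numbers for stronger inhibition of growth:
compound 1 `Cc1ccccc1Nc1nc(NC2CCCCC2)ncc1Cl`: > 100000 nM
compound 2 `CCN1CCN(c2ccc(Nc3ncc(Cl)c(Nc4ccccc4C)n3)nc2)CC1`: > 100000 nM

Neither entry is a number, because each is a limit: the limit of > 100000 nM in this assay, at which 2 of the 2 values shown sit. Compound 2 therefore has no position beyond its limit of > 100000 nM.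

Compound 3 `Cc1ccccc1Nc1nc(Nc2ccc(N3CCCCC3)cn2)ncc1Cl` has piperidin-1-yl in place of 4-ethylpiperazin-1-yl on an aromatic carbon. No measured step sizes this change. With the limit of compound 2 at > 100000 nM, the only direction open is toward stronger inhibition in this assay, so a modest move that way is expected, though compound 3 may also stay at the limit. The estimated change is an at least 3.3-fold lower number from compound 2 to compound 3 (0.52 log units; beyond the scatter). For compound 3 the expected value is 30000 nM, with an estimated range of 5000 nM to 100000 nM.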

Compound 3, concentration for 50% growth inhibition: > 100000 nM
Compound 3 was reported as a limit; the forecaster's own chance of this, stated with the estimate: 50%; middle value at least 3.3-fold (0.52 log units) away from the limit.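

No step can be read from compound 2 to compound 3, because both results are limits: the limit of > 100000 nM in this assay, at which 3 of the 3 values shown sit.
The compounds shown leave open whether piperidin-1-yl and 4-ethylpiperazin-1-yl differ at all, and what change to the series would bring a measurable value.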